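A few compounds are considered here, and "the series" means these few. Any claim that something is new, unique, unknown or untested is made for them only; others in the source may bear on it.

Going by the values given here, compound 1 `O=C1CC(c2c(-c3ccc[nH]3)[nH]c3ccccc23)C(=O)N1` is the one compound among the three measured here that yields a number in a functional assay on U-373MG ATCC cells (Homo sapiens) for cytotoxicity, read by MTT assay, with a stated time of 72 h; a higher number here means a weaker inhibitor, a lower number a stronger inhibitor: compound 1 gives 4000 nM. Compound 3 `O=C1NC(=O)c2c1c1[nH]ncc1c1[nH]c3ccccc3c21` reaches only a limit of this assay, > 100000 nM, so no number is known for it. Compound 2 `Cc1ccc2[nH]c3c4cn[nH]c4c4c(c3c2c1)C(=O)NC4=O` likewise reaches only a limit of this assay, > 100000 nM. Compound 2 differs from compound 3 by one change, (methyl in place of hydrogen on an aromatic carbon), and the step from compound 3 to compound 2 is a step that the two limits leave unreadable from compound 3 to compound 2 because of the limit of > 100000 nM in this assay, at which 2 of the 3 values shown sit. How the core of compound 1 differs from the core of compound 3 is not broken down here; the two cores simply differ in more than one place.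

Compound 4 `Cc1ccc2[nH]c(-c3ccc[nH]3)c(C3CC(=O)NC3=O)c2c1` has not been measured. It differs from compound 1 by methyl in place of hydrogen on an aromatic carbon. This is the same kind of change as that from compound 3 to compound 2, but not the same: in compound 4 the ring carrying the methyl is part of a fused or bridged system of two rings, whereas in compound 2 it is part of a fused or bridged system of five rings. Among the compounds with values here, the one measured instance of this kind of change is unreadable, so the expectation rests on compound 1 giving 4000 nM and on the methyl adding a single carbon with no donor or acceptor. In this assay compound 4 is expected to give an estimated 3500 nM, with a range from 1500 nM to 9000 nM. The expected step is a 1.1-fold lower number from compound 1 to compound 4 (0.06 log units; within the scatter).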

Compound 4, half-maximal inhibitory concentration: 5000 nM
Beside the measured number, compound 4's estimate is 1.4-fold (0.15 log units) below it; measured number inside the range.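

Methyl in place of hydrogen on an aromatic carbon gives, in this assay, a 1.3-fold higher number from compound 1 to compound 4 (0.10 log units; within the scatter), so on this core the change leaves the number where it was, as far as the scatter allows anyone to tell. Going by these compounds alone, the only other instance of the change, on the core of compound 3, cannot be read because compound 3 and compound 2 both stand at a limit of the assay and not at a number: the limit of > 100000 nM in this assay, at which 2 of the 4 values shown sit. The result therefore shows that one core accepts this methyl without a readable shift, but it does not show that the change carries over from one core to another, as one readable step cannot be set against one unreadable step.

What an ethyl, a methoxy, an amine or a carboxylic acid would do at the same aromatic carbon in this assay stays open, as the only group shown entering there is a methyl. Also open, from the compounds shown here alone, is what a methyl would do on the other carbons of that six-membered ring, and whether the change would give a readable step on a core other than that of compound 1.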